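The source may report more compounds than this note shows. Statements on the series, on what has been measured and on what is new or still open speak of the compounds shown alone.

Measured compounds:
- compound 1 `COC1CN(C(=O)/C=C/c2ccncc2-c2ccc3[nH]ncc3c2)C1` gives 98%
- compound 2 `COC1CN(C(=O)/C=C/c2ccncc2-c2ccc3ccccc3c2)C1` gives 100%
- compound 3 `CNC(=O)/C=C/c1ccncc1-c1ccc2c(cnn2C)c1` gives 98%

In an assay on a protein complex for inhibition of CDK8/Cyclin C (Homo sapiens), with a stated time of 1 h, tested at 10 uM (on this read-out lower numbers stand for less inhibition and higher numbers for more inhibition at the one concentration tested (going by the name of the read-out)), compound 2 gives 100%, the highest of the three numbers, though the other two lie within the scatter of it: compound 1 gives 98% and compound 3 gives 98%. No ranking among the three can be drawn from these numbers. Going by the values given here, no pair of measured compounds differs in one place, so no measured step exists to set a scale for the change at hand.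

Compound 4 `O=C(O)/C=C/c1ccncc1-c1ccc2ccccc2c1` has not been measured. It differs from compound 2 in one place: hydroxy in place of 3-methoxyazetidin-1-yl on a carbonyl carbon. The remainder of compound 2 is kept. With all three measured numbers close to the top of the read-out, a change in this assay can only show as a drop, and a drop beyond the scatter is expected, of the size a number 25 percentage points lower from compound 2 to compound 4 (beyond the scatter). Compound 4 is estimated at 75%, with a range from 35% to 98%; the range is wide, as nothing measured here bears on a carboxy at this place.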

Compound 4, a percentage reported as inhibition, at one concentration (the size of the read-out at that concentration, not a potency): 102%
The estimate for compound 4 lay 27 percentage points below the measured number, outside the stated range (above it).
By their numbers in this assay, from the lowest: compounds 1, 3, 2 and 4 (each within the scatter of the next).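

In this assay, hydroxy in place of 3-methoxyazetidin-1-yl on a carbonyl carbon gives a number 2 percentage points higher from compound 2 to compound 4 (within the scatter), the first one-place step available in the series. At the one concentration tested, the read-out therefore does not depend on keeping the 3-methoxyazetidin-1-yl group at this place: the ring and its methoxy can go, and the carboxy of compound 4 leaves the number within the scatter of compound 2. Nothing shown here gives a reason for this result.

With the numbers this close to the top of the read-out at a single concentration, any difference in potency between compound 2 and compound 4 stays unresolved. Also open, as far as these compounds go, is whether a methyl ester, a primary amide or a longer chain ending in a carboxylic acid on this carbonyl carbon would hold the number.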